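This account rests on a few compounds, and the source may have more. Where it says the series, first, only, none or still open, it means among the compounds named here.

Measured so far in an ADME assay on cells (Hepatocyte, Homo sapiens) for metabolic stability; on this read-out higher numbers stand for a longer-lived compound and lower numbers for a shorter-lived compound:
compound 1 `N#Cc1cnc(N2CCC(C(=O)N3N=CC[C@H]3c3cc(F)cc(F)c3)CC2)cn1`: 3.3 h
compound 2 `Cc1nnc(N2CCC(C(=O)N3N=CC[C@H]3c3cc(F)cc(F)c3)CC2)o1`: 3.3 h
compound 3 `N#Cc1nccc(N2CCC(C(=O)N3N=CC[C@H]3c3cc(F)cc(F)c3)CC2)n1`: 2.1 h

Compound 3, at 2.1 h, holds no distinct place in this small set. The measured 1.6-fold lower number from compound 1 to compound 3 (0.20 log units; within the scatter) and a 1.6-fold lower number from compound 2 to compound 3 (0.20 log units; within the scatter) both lie within the scatter, so the three compounds cannot be told apart on these numbers.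

The next compound is compound 4 `N#Cc1cc(N2CCC(C(=O)N3N=CC[C@H]3c3cc(F)cc(F)c3)CC2)ncn1`. It keeps the shared core of compound 3 and alters only the group on the amine nitrogen in a ring: a group of 8 heavy atoms (5 carbon, 3 nitrogen; one six-membered aromatic ring with 2 hetero atoms) in place of a group of 8 heavy atoms (5 carbon, 3 nitrogen; one six-membered aromatic ring with 2 hetero atoms), on an amine nitrogen in a ring. The two have the same atoms, joined differently.

All three measured steps bear on this change, as each swaps the group at this same place. Besides the two steps above, there is no change at the digits printed from compound 1 to compound 2 (within the scatter). The 5-cyanopyrazin-2-yl of compound 1 and the 2-cyanopyrimidin-4-yl of compound 3 are the closest groups to the one entering, and the step between them stayed within the scatter. Even the 5-methyl-1,3,4-oxadiazol-2-yl of compound 2 left the number within the scatter. Within the data shown here, with only three values, this is thin evidence, and none of them comes from this exact rearrangement.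

No change beyond the scatter is therefore expected, and the expected size is a 1.3-fold higher number from compound 3 to compound 4 (0.11 log units; within the scatter). In this assay the estimate for compound 4 is 2.7 h, with an expected range of 1.4 h to 5 h.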

Compound 4, half-life: 3.3 h
Compound 4: middle estimate off by 1.2-fold (0.09 log units), on the low side; measured number inside the range.
By their numbers in this assay, from the lowest: compounds 3, 1, 2 and 4 (each within the scatter of the next).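

In this assay, the group entering in compound 4 adds a third arrangement of the same atoms at this place on the amine nitrogen in a ring, and the two steps from the other arrangements both stay within the scatter: a 1.6-fold higher number from compound 3 to compound 4 (0.20 log units; within the scatter) and no change at the digits printed from compound 1 to compound 4 (within the scatter). The step from the smaller five-membered 5-methyl-1,3,4-oxadiazol-2-yl group reads the same way, with no change at the digits printed from compound 2 to compound 4 (within the scatter), so neither rearranging these atoms nor exchanging the ring type has yet separated any of the compounds on this read-out. All four compounds therefore remain one group in this assay, and no accompanying measurement is available to explain this flat picture.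

Every group shown at this place is an aromatic ring with hetero atoms, so it remains open whether the half-life would stay in the same band with an acetyl group, or with a ring carrying an amine or a carboxylic acid. The rest of the shared core is identical throughout, which leaves open how the half-life responds to a change anywhere else in the series.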